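Isopropoxy to ethoxy on the shared core

The source may hold more compounds than are shown below. What is called first, only, known or untested is meant among the compounds shown, and "the series" means these compounds.

Among the compounds with values here, in a functional assay on thoracic aorta (Rattus norvegicus, strain Wistar), with a stated time of 15 min (a higher number here means that more compound is needed for the effect, a lower number that less compound is needed), compound 1 `CC(C)Oc1ccc(Br)cc1C(C)NC(=O)N(C)S(=O)(=O)c1ccccc1` gives 32100 nM, within the scatter of the only other measured compound, compound 2 `Cc1ccc(S(=O)(=O)N(C)C(=O)NC(C)c2cc(Br)ccc2OC(C)C)cc1`, at 34700 nM. Compound 3 `CCOc1ccc(Br)cc1C(C)NC(=O)N(C)S(=O)(=O)c1ccccc1` differs from compound 1 as isopropoxy to ethoxy: hydrogen in place of methyl on a saturated chain carbon bound to an oxygen on an aromatic ring and a saturated chain carbon. Within the data shown here, no measured step touches that group. Among the measured compounds shown here, the one available step, a 1.1-fold higher number from compound 1 to compound 2 (0.03 log units; within the scatter), is methyl in place of hydrogen on an aromatic carbon, so it offers only weak guidance. No step beyond the scatter is therefore expected in this assay, and no direction is favoured. The estimated step is a 1.0-fold higher number from compound 1 to compound 3 (0.01 log units; within the scatter). For compound 3 the estimated value is 33000 nM, with an expected range of 13000 nM to 80000 nM.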

Compound 3, half-maximal effective concentration: 19800 nM
The estimate for compound 3 lay 1.7-fold (0.22 log units) above the measured number, and the stated range covers the measured number.
By their numbers in this assay, from the lowest: compounds 3, 1 and 2 (each within the scatter of the next).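

Among the compounds shown, only this step touches the isopropoxy group: shortening it to ethoxy gives a 1.6-fold lower number from compound 1 to compound 3 (0.21 log units; within the scatter) in this assay. Losing this methyl from the saturated chain carbon therefore leaves the number within the scatter, so the position tolerates this one small change in this assay. No measured evidence offers an explanation for this result. Still open, as far as these compounds go, is whether a longer chain such as butoxy, or an amine in place of isopropoxy, would move the number beyond the scatter. Also open, from the compounds shown here alone, is whether ethoxy would give a similar number on the core of compound 2.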